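The source may report more compounds than this note shows. Statements on the series, on what has been measured and on what is new or still open speak of the compounds shown alone.

Measured compounds, by the half-maximal inhibitory concentration in an assay on isolated protein for inhibition of ubiquitin carboxyl-terminal hydrolase 7 (Homo sapiens), with stated times of 30 min and 2 h; on this read-out lower numbers stand for stronger inhibition and higher numbers for weaker inhibition:
- compound 1, `Cn1nc2c(=O)n(CC3(O)CCN(Cc4ccc(-c5ccco5)cc4Cl)CC3)cnc2c1-c1ccc(Cl)cc1`: 143 nM
- compound 2, `Cn1nc2c(=O)n(CC3(O)CCN(Cc4ccc(C5CCCO5)cc4Cl)CC3)cnc2c1-c1ccc(CN)cc1`: 3820 nM
- compound 3, `Cn1nc2c(=O)n(CC3(O)CCN(Cc4ccc(-c5ccoc5)cc4Cl)CC3)cnc2c1-c1ccc(CN)cc1`: 177 nM

Compound 1 gives the lowest number of the three in this assay, though the values of compound 1 and compound 3 lie within the scatter of each other, so no order between them can be claimed. Among the measured compounds shown here, compound 2 sits far higher; the only single-point step in the set, a 22-fold lower number from compound 2 to compound 3 (1.33 log units; beyond the scatter), concerns the furan site and not the aryl carried on the shared core.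

Compound 4, `Cn1nc2c(=O)n(CC3(O)CCN(Cc4ccc(-c5ccco5)cc4Cl)CC3)cnc2c1-c1ccc(CNC2CC2)cc1`, is derived from compound 1 by one change: (cyclopropylamino)methyl in place of chloro on an aromatic carbon. For the measured compounds named here, no measured step addresses this position directly. What the data do show is that compound 3, carrying aminomethyl rather than chloro on that ring together with a different furan attachment, gives a value close to that of compound 1. An amine-bearing substituent at this place is therefore tolerated in at least one case, and for the cyclopropylamino variant a step within the scatter is expected, a 1.0-fold higher number from compound 1 to compound 4 (0.02 log units; within the scatter). Compound 4 is thus estimated at 150 nM, in a range from 60 nM to 400 nM.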

Compound 4, half-maximal inhibitory concentration: 54.1 nM
The estimate for compound 4 lay 2.8-fold (0.44 log units) above the measured number; measured number below the stated range.
By their numbers in this assay, from the lowest: compound 4; then compounds 1 and 3 (each within the scatter of the next); then compound 2.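

In this assay, among the compounds shown here, putting (cyclopropylamino)methyl in place of chloro gives a 2.6-fold lower number from compound 1 to compound 4 (0.42 log units; beyond the scatter), the only step in the set read directly at this position on the six-membered aromatic ring. It shows that, with the rest of compound 1 unchanged, the larger group, with its three-membered ring and the hydrogen-bond donor and acceptor that chloro lacks, goes with a modest drop in the number beyond the scatter, rather than merely being accepted. Nothing measured here accounts for this step.

From the compounds shown here alone, whether the cyclopropyl ring or the amine nitrogen carries the step remains open, as does whether it would hold with the furan-3-yl group of compound 3. Going by these compounds, how (dimethylamino)methyl or a carboxylic acid would compare at this position also remains unknown.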